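This account rests on a few compounds, and the source may have more. Where it says the series, first, only, none or still open, it means among the compounds named here.

For the measured compounds named here, in a functional assay on HCT-15 cells (Homo sapiens) for antiproliferative activity (a higher number here means a weaker inhibitor of growth, a lower number a stronger inhibitor of growth), compound 2 `c1ccc(-c2cc(-c3cccs3)cc(-c3ccccn3)n2)nc1` gives 0.11 ug/mL, the lowest of the two numbers measured so far; the nearest is compound 1 `c1ccc(-c2cc(-c3ccsc3)cc(-c3ccccn3)n2)nc1` at 0.29 ug/mL, and the only measured step, a 2.6-fold lower number from compound 1 to compound 2 (0.42 log units; beyond the scatter), was modest. Compound 3 `c1ccc(-c2cc(-c3ccco3)cc(-c3ccccn3)n2)nc1` differs from compound 2 by furan-2-yl in place of thiophen-2-yl on an aromatic carbon. Going by the values given here, no measured step exchanges one heteroatom in this five-membered ring for another, so the single step offers only indirect guidance. For compound 3 the expected step is therefore a 1.8-fold higher number from compound 2 to compound 3 (0.26 log units; within the scatter), likely within or near the scatter. Compound 3 is estimated at 0.2 ug/mL, with a range from 0.07 ug/mL to 0.6 ug/mL.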

Compound 3, concentration for 50% growth inhibition: 0.1 ug/mL
Compound 3: the middle estimate sits 2.0-fold (0.30 log units) above what was measured; the measured number falls inside the stated range.
By their numbers in this assay, from the lowest: compounds 3 and 2 (each within the scatter of the next); then compound 1.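

In this assay, the exchange of thiophen-2-yl for furan-2-yl opposite the ring nitrogen gives a 1.1-fold lower number from compound 2 to compound 3 (0.04 log units; within the scatter) and so leaves the number unchanged within the scatter. The other new step, a 2.9-fold lower number from compound 1 to compound 3 (0.46 log units; beyond the scatter) for furan-2-yl against thiophen-3-yl, matches the earlier gap, so among these three compounds only compound 1 stands apart. Nothing available explains this result. The compounds shown leave open whether a six-membered ring such as phenyl, or a saturated amine such as morpholine, would keep these low numbers at this place.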